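This account rests on a few compounds, and the source may have more. Where it says the series, first, only, none or still open, it means among the compounds named here.

Working notes on a small hydrazone series. Compound 1 `Cc1ccc(C(=O)N/N=C/c2ccccc2)c(O)c1`, compound 2 `Cc1ccc(C(=O)N/N=C/c2ccccc2O)c(O)c1` and compound 3 `Cc1ccc(C(=O)N/N=C/c2cc(Br)ccc2O)c(O)c1` share one core and have each been run in an ADME assay on cells (Mus musculus, strain BALB/C) for cytotoxicity, read by MTT assay, with a stated time of 24 h; on this read-out higher numbers stand for lower toxicity in this test and lower numbers for higher toxicity in this test. In this assay compound 1 gives 578000 nM, compound 2 gives 761000 nM and compound 3 gives 1500000 nM. a 1.3-fold lower number from compound 2 to compound 1 (0.12 log units; within the scatter), the change being (hydrogen in place of hydroxy on an aromatic carbon). a 2.0-fold higher number from compound 2 to compound 3 (0.29 log units; within the scatter), the change being (bromo in place of hydrogen on an aromatic carbon); this is also how the core of compound 3 differs from that of compound 2. Compound 3 holds the highest number of the three, but only its gap to compound 1 lies beyond the scatter.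

Compound 4 `Cc1ccc(C(=O)N/N=C/c2cccc(Br)c2)c(O)c1` is not yet measured. It is reached from compound 3 by hydrogen in place of hydroxy on an aromatic carbon. The site is the same kind as in the step from compound 2 to compound 1, not the same: in compound 3 it is also para to a bromo group. The step of a 1.3-fold lower number from compound 3 to compound 4 (0.12 log units; within the scatter) is expected to be small because the matching step a 1.3-fold lower number from compound 2 to compound 1 (0.12 log units; within the scatter) stayed within the scatter. Compound 4 is accordingly estimated at 1150000 nM, between 550000 nM and 2600000 nM.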

Compound 4, half-maximal cytotoxic concentration: 113000 nM
Beside the measured number, compound 4's estimate is 10-fold (1.01 log units) above it; the whole stated range lies above it.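

On the bromo-bearing core, hydrogen in place of hydroxy gives a 13-fold lower number from compound 3 to compound 4 (1.12 log units; beyond the scatter), which does not match the same change on the core without bromo: the same change on two cores in this assay, a 1.3-fold lower number (0.12 log units; within the scatter) from compound 2 to compound 1 and a 13-fold lower number (1.12 log units; beyond the scatter) from compound 3 to compound 4, 10-fold (1.00 log units) apart, beyond the scatter of two such steps

Bromo in place of hydrogen, on the core without the hydroxy, gives a 5.1-fold lower number from compound 1 to compound 4 (0.71 log units; beyond the scatter), and this too differs from the same change on the core with the hydroxy: the same change on two cores in this assay, a 2.0-fold higher number (0.29 log units; within the scatter) from compound 2 to compound 3 and a 5.1-fold lower number (0.71 log units; beyond the scatter) from compound 1 to compound 4, 10-fold (1.00 log units) apart, beyond the scatter of two such steps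

In this assay, neither change can therefore be carried from one core to another as a fixed step among these four compounds, and the effect of each depends on whether the other group is present; this single set of four does not show the reason for that dependence or how either change behaves on any other core.

The compounds shown leave open whether the large step is tied to the hydroxy itself or would also appear with a methoxy or an amine at that site. They also leave open whether chloro or methyl in place of bromo would give the same dependence.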